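Shifting the Methoxy Group From Compound 3 to Compound 4

The source may report more compounds than this note shows. Statements on the series, on what has been measured and on what is new or still open speak of the compounds shown alone.

In a functional assay on A-431 cells (Homo sapiens) for cytotoxicity (a higher number here means that more compound is needed for the effect, a lower number that less compound is needed), compound 1 `COC1=C(C)C(=O)/C(=C(O)/C=C/c2ccc(Br)cc2)C(=O)C1(C)C` gives 9 ug/mL, compound 2 `COC1=C(C)C(=O)/C(=C(O)/C=C/c2ccc(OC)cc2)C(=O)C1(C)C` gives 9.2 ug/mL and compound 3 `COC1=C(C)C(=O)/C(=C(O)/C=C/c2cccc(OC)c2)C(=O)C1(C)C` gives 4.5 ug/mL. That places compound 3 at the low end of the three numbers, though the margins are slim: a 2.0-fold lower number from compound 2 to compound 3 (0.31 log units; beyond the scatter), and a 2.0-fold lower number from compound 1 to compound 3 (0.30 log units; within the scatter).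

Compound 4 `COC1=C(C)C(=O)/C(=C(O)/C=C/c2ccccc2OC)C(=O)C1(C)C` carries 2-methoxyphenyl in place of 3-methoxyphenyl on a double-bonded chain carbon bound to a double-bonded chain carbon. Within the data shown here, the closest precedent is the swap of 4-methoxyphenyl for 3-methoxyphenyl, which gave a 2.0-fold lower number from compound 2 to compound 3 (0.31 log units; beyond the scatter). The exchange of bromo for methoxy gave a 1.0-fold higher number from compound 1 to compound 2 (0.01 log units; within the scatter). Among the measured compounds shown here, both changes on this aromatic ring were small, so a small step is the reasonable expectation here, although no compound with 2-methoxyphenyl has yet been measured to settle the direction. With compound 3 at the low end of the three, a slight rise seems the likelier outcome. The expected step is a 1.3-fold higher number from compound 3 to compound 4 (0.12 log units; within the scatter). For compound 4 the estimated value in this assay is 6 ug/mL, with an expected range of 3 ug/mL to 12 ug/mL.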

Compound 4, concentration for half-maximal effect: 6.6 ug/mL
Compound 4: middle estimate off by 1.1-fold (0.04 log units), on the low side, and the stated range covers the measured number.
By their numbers in this assay, from the lowest: compounds 3, 4, 1 and 2 (each within the scatter of the next, the first and the last beyond it).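

In this assay, the 2-methoxyphenyl group of compound 4 cannot be told apart from the other two methoxyphenyl or bromophenyl groups, with a 1.5-fold higher number from compound 3 to compound 4 (0.17 log units; within the scatter) and a 1.4-fold lower number from compound 2 to compound 4 (0.14 log units; within the scatter) both lying within the scatter. The same holds for a 1.4-fold lower number from compound 1 to compound 4 (0.13 log units; within the scatter) against the bromo compound. The only gap that so far reaches beyond the scatter, a 2.0-fold lower number from compound 2 to compound 3 (0.31 log units; beyond the scatter) in size, is therefore modest, and the new compound can be placed on neither side of it, so the methoxy group's place on this ring has shown little influence on the number.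

Going by these compounds, whether a different group on this ring, such as an amine or a carboxylic acid, or a longer chain in place of methoxy, would give a clearer step stays open. Nothing available explains the small differences seen among these compounds.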